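From Compound 3 to Compound 4: A Methoxy Step

The source may hold more compounds than are shown below. What is called first, only, known or untested is meant among the compounds shown, and "the series" means these compounds.

In a functional assay on Jurkat cells (Homo sapiens) for cytotoxicity, read by MTT assay, with a stated time of 72 h (a higher number here means a weaker inhibitor, a lower number a stronger inhibitor), compound 3 `O=C(CCc1ccc(NC(=O)Nc2ccccc2)cc1)NO` gives 1590 nM, while compound 1 `O=C(Nc1ccccc1)Nc1ccc(C(=O)NO)cc1` gives 2500 nM. With 2-(hydroxycarbamoyl)ethyl in place of hydroxycarbamoyl on an aromatic carbon, the move is a 1.6-fold lower number from compound 1 to compound 3 (0.20 log units; within the scatter), so these two compounds stand level. Compound 2 `COc1ccc(NC(=O)Nc2ccc(C(=O)NO)cc2)cc1` stands apart from both at 8030 nM, a higher number than either.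

The next structure, compound 4 `COc1ccc(NC(=O)Nc2ccc(CCC(=O)NO)cc2)cc1`, carries methoxy in place of hydrogen on an aromatic carbon, para to a large group: methoxy in place of hydrogen on an aromatic carbon. The same replacement has been measured only once, and that measurement gives a 3.2-fold higher number from compound 1 to compound 2 (0.51 log units; beyond the scatter), a modest step beyond the scatter. The change of side chain that links compound 1 to compound 3 stayed within the scatter, which gives some ground for carrying the methoxy step across. Still, this is a single pair, and the data do not show whether the step holds when 2-(hydroxycarbamoyl)ethyl is present. A step in the same direction, towards a higher number, but somewhat smaller, is therefore expected. The estimated move is a 2.6-fold higher number from compound 3 to compound 4 (0.42 log units; beyond the scatter). In this assay, compound 4 is expected at 4200 nM, with an estimated range of 1900 nM to 9000 nM.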

Compound 4, half-maximal inhibitory concentration: 2800 nM
Estimate against measurement, compound 4: 1.5-fold (0.18 log units) above, and the stated range covers the measured number.
By their numbers in this assay, from the lowest: compounds 3, 1 and 4 (each within the scatter of the next); then compound 2.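

With compound 4, the change from phenyl to 4-methoxyphenyl has a second reading in this assay, and on this core it is a 1.8-fold higher number from compound 3 to compound 4 (0.25 log units; within the scatter), so the methoxy step does not clear the scatter here as it did on the core of compound 1. Even so, the two readings do not part far enough to show that the core changes what methoxy does at this position: the same change on two cores in this assay, a 3.2-fold higher number (0.51 log units; beyond the scatter) from compound 1 to compound 2 and a 1.8-fold higher number (0.25 log units; within the scatter) from compound 3 to compound 4, 1.8-fold (0.26 log units) apart, within the scatter of two such steps. The side-chain change also gains a second reading, a 2.9-fold lower number from compound 2 to compound 4 (0.46 log units; beyond the scatter), which lies beyond the scatter where its first reading did not, yet these two readings also fail to separate: the same change on two cores in this assay, a 1.6-fold lower number (0.20 log units; within the scatter) from compound 1 to compound 3 and a 2.9-fold lower number (0.46 log units; beyond the scatter) from compound 2 to compound 4, 1.8-fold (0.26 log units) apart, within the scatter of two such steps.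

Methoxy is the only group shown at this position, so it remains open how an amine, a carboxylic acid or a chlorine atom there would read on either core. A longer chain in place of 2-(hydroxycarbamoyl)ethyl also remains open, and with only two cores and a single read-out, the compounds shown cannot tell whether either step would hold more widely.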